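A few compounds are considered here, and "the series" means these few. Any claim that something is new, unique, unknown or untested is made for them only; others in the source may bear on it.

Measured compounds:
- compound 1, `COc1ccc(-n2nc(C(=O)Nc3ccncc3)cc2-c2ccc(Cl)cc2)nn1`, 110 nM
- compound 2, `COc1ccc(-n2nc(C(=O)N3CCN(c4ccc(C)cc4)CC3)cc2-c2ccc(Cl)cc2)nn1`, 4670 nM

In a functional assay on a cell-free system (Platelet, plasma, Homo sapiens) for inhibition, read by turbidimetry, with a stated time of 3 min (a higher number here means a weaker inhibitor, a lower number a stronger inhibitor), compound 1 gives 110 nM, the lowest of the two numbers at hand. Compound 2 gives 4670 nM in the same assay, and the gap between these two values lies well beyond the ordinary scatter, so compound 1 is the stronger inhibitor of the pair. Among the compounds with values here, no single-point steps between measured compounds are available, so the two values can only be read side by side.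

Compound 3, `COc1ccc(-n2nc(C(=O)N3CCCC3)cc2-c2ccc(Cl)cc2)nn1`, has not yet been measured. It differs from compound 1 at one place: pyrrolidin-1-yl in place of (pyridin-4-yl)amino on a carbonyl carbon. The amide in compound 1 carries a hydrogen and an aromatic ring, while compound 3 carries a saturated ring closed through the amide nitrogen. Within the data shown here, compound 2, the only other measured compound, also has its amide nitrogen inside a saturated ring, and it is a much weaker inhibitor than compound 1.

On that basis the step in this assay from compound 1 to compound 3 is expected to be upward, toward a weaker inhibitor, a 14-fold higher number from compound 1 to compound 3 (1.13 log units; beyond the scatter), though with wide uncertainty. The value expected for compound 3 is 1500 nM, within a range from 300 nM to 8000 nM.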

Compound 3, half-maximal inhibitory concentration: 15 nM
Estimate against measurement, compound 3: 100-fold (2.00 log units) above; measured number below the stated range.
By their numbers in this assay, from the lowest: compound 3; then compound 1; then compound 2.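

In this assay, pyrrolidin-1-yl in place of (pyridin-4-yl)amino on the carbonyl carbon gives a 7.3-fold lower number from compound 1 to compound 3 (0.87 log units; beyond the scatter), so neither the amide hydrogen nor the pyridine ring is needed for strong inhibition in this series. Compound 2 also has its amide nitrogen inside a saturated ring and gives 4670 nM, whereas compound 3 gives 15 nM, so a saturated ring at this nitrogen does not by itself mean weak inhibition, and what else that ring carries may matter a great deal. No measurement shown here explains why this change strengthens inhibition.

The change removes the amide hydrogen and the pyridine ring together, so their separate contributions cannot be told apart; a methyl group on the amide nitrogen of compound 1 would keep the pyridine ring while removing that hydrogen. How far the trend extends also remains open, since the compounds shown do not include close relatives of the pyrrolidine such as azetidin-1-yl, piperidin-1-yl or morpholin-4-yl, which would test the size and make-up of this ring.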